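Swapping methyl for fluoro on compound 3

A few compounds are considered here, and "the series" means these few. Any claim that something is new, unique, unknown or untested is made for them only; others in the source may bear on it.

Measured in a functional assay on B16 cells (Mus musculus) for cytotoxicity, read by CCK-8 assay, with a stated time of 24 h; on this read-out lower numbers stand for stronger inhibition and higher numbers for weaker inhibition:
- compound 1 `COc1ccccc1Oc1c(N)nc(-c2cccc(C)c2)nc1Cl` gives 13100 nM
- compound 2 `COc1ccc(-c2nc(N)c(Oc3ccccc3OC)c(Cl)n2)cc1` gives 47800 nM
- compound 3 `COc1ccccc1Oc1c(N)nc(-c2cccc(C)c2)nc1OCCO` gives 70900 nM

Compound 3 and compound 2 lie within the usual scatter of each other, while compound 1 stands clearly apart, with a 5.4-fold higher number from compound 1 to compound 3 (0.73 log units; beyond the scatter). Compound 4 `COc1ccccc1Oc1c(N)nc(-c2cccc(F)c2)nc1OCCO` has fluoro in place of methyl on an aromatic carbon, (fluoro in place of methyl on an aromatic carbon). Within the data shown here, no measured step makes this exact swap. The closest replaces the whole 3-methylphenyl with 4-methoxyphenyl, a 3.6-fold higher number from compound 1 to compound 2 (0.56 log units; beyond the scatter), and even that step is only modest. A smaller change is therefore expected here, with no clear direction in this assay. The expected step is a 1.1-fold lower number from compound 3 to compound 4 (0.04 log units; within the scatter). For compound 4 the estimated value is 65000 nM, with an expected range from 28000 nM to 150000 nM.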

Compound 4, half-maximal inhibitory concentration: 20900 nM
Compound 4: middle estimate off by 3.1-fold (0.49 log units), on the high side; measured number below the stated range.
By their numbers in this assay, from the lowest: compounds 1 and 4 (each within the scatter of the next); then compounds 2 and 3 (each within the scatter of the next).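

In this assay, going from 3-methylphenyl to 3-fluorophenyl gives a 3.4-fold lower number from compound 3 to compound 4 (0.53 log units; beyond the scatter), so swapping a single heavy atom on this aromatic ring is enough to move the number beyond the scatter. Among these compounds, the only earlier change at this ring replaced the whole 3-methylphenyl with 4-methoxyphenyl and raised the number, though on the chloro compounds, whereas this one lowers it. No measurement here explains this difference. On these data alone, whether fluoro gives the same step with chloro in place of 2-hydroxyethoxy stays open, as does what a trifluoromethyl or an amine would give on this ring carbon.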